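The compounds below may be only part of what the source reports. "The series", "measured", "known", "first", "only" and "open" are said of these compounds alone.

In a functional assay on NRK-52E cells (Rattus norvegicus), with stated times of 5 min and 72 h (a lower number here means that less compound is needed, a higher number that more compound is needed for the effect), compound 3, whose structure is `CC1=CC(=O)CC(C)(C)[C@@H]1CO[C@@H]1O[C@H](CO)[C@@H](O)[C@H](O)[C@H]1O`, gives > 100000 nM, and that is a limit of the assay rather than a number. Compound 1, with the structure `CC1=C(C(=O)O[C@@H]2O[C@H](CO)[C@@H](O)[C@H](O)[C@H]2O)C(C)(C)CC[C@@H]1O`, also returns a limit in this assay, at > 100000 nM. Compound 2, drawn as `CC1=CC(=O)CC(C)(C)[C@]1(O)CO`, likewise sits at a limit in this assay, at > 100000 nM. So compound 3 stands together with the other two measured compounds (the limit of > 100000 nM in this assay, at which 3 of the 3 values shown sit), and no compound in this set has shown a measurable effect.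

Compound 4, whose structure is `CC1=CC(=O)CC(C)(C)[C@H]1CO[C@@H]1O[C@H](CO)[C@@H](O)[C@H](O)[C@H]1O`, is the next one to be tested. The difference from compound 3 is this: the two compounds have the same atoms and bonds and differ only in configuration as drawn: 1 of 6 stereo elements differ; a stereocentre at a saturated ring carbon is drawn S in compound 3 and R in compound 4. Nothing is added and nothing is taken away; the two molecules are mirror-related at a single stereocentre on a saturated ring carbon, while everything else, including the sugar part, is kept as it is.

Among the measured compounds shown here, since no two measured compounds here differ in a single place, there is no earlier step to lean on. With every measured value resting at the limit of this assay, the most that can be expected is that compound 4 stays there as well, and the step is estimated to be a step that the limit leaves unreadable from compound 3 to compound 4, meaning no change beyond the scatter. Compound 4 is accordingly expected to reach about 150000 nM, within a range from 30000 nM to 500000 nM.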

Compound 4, half-maximal effective concentration: 1200 nM
Beside the measured number, compound 4's estimate is 130-fold (2.10 log units) above it, outside the stated range (below it).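

In this assay, among the compounds shown here, redrawing one stereocentre at a saturated ring carbon from S to R gives an at least 83-fold lower number from compound 3 to compound 4 (1.92 log units; beyond the scatter), the only change in this set that produces a measurable effect. Nothing else separates the two molecules, so the sugar part, the ring carbonyl and the rest of the shared core cannot on their own account for this gain, and the spatial arrangement at this single carbon decides whether a value can be read at all: the fact that compounds 3 and 4 differ only in the configuration as drawn. Compound 4 also stands apart from every other compound shown, as the only one with a value that is a real number rather than a limit: the limit of > 100000 nM in this assay, at which 3 of the 4 values shown sit.

As far as these compounds go, it remains open whether the effect of compound 4 depends on the sugar part or would survive with a smaller group, such as a methyl group or an acetyl group, in its place while the R configuration is kept. From the compounds shown here alone, the exact size of the step also remains open: compound 3 gives > 100000 nM, which is a limit of the assay.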